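This account rests on a few compounds, and the source may have more. Where it says the series, first, only, none or still open, it means among the compounds named here.

Working notes on the series in a functional assay (spleen, spleen) for activation, with Mus musculus as the target; on this read-out higher numbers stand for an effect only at larger amounts of compound and lower numbers for an effect already at smaller amounts. Going by the values given here, compound 1, `Cc1ccc(Cn2c(O)nc3c(N)ncnc32)cc1`, gives 10 uM in this assay, and this is the only number in the set so far. Compound 2, `Nc1ncnc2c1nc(Cl)n2Cc1ccccc1`, returns a limit rather than a number in this assay, > 10 uM. That reading corresponds to the limit of > 10 uM in this assay, at which 1 of the 2 values shown sits, and it marks where one of the two values shown sits. Among the compounds with values here, no step between measured compounds exists, so no measured change can be carried across to a new compound.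

Compound 3, `Nc1ncnc2c1nc(O)n2Cc1ccc(F)cc1`, is not yet measured. It differs from compound 1 by fluoro in place of methyl on an aromatic carbon; the change sits on an aromatic carbon of a six-membered aromatic ring of carbon only, para to a large group. For this assay the expected step from compound 1 to compound 3 is no change at the digits printed from compound 1 to compound 3 (within the scatter), which is expected to stay within the usual scatter. On that basis compound 3 is estimated at 10 uM in this assay, with a range from 5 uM to 20 uM. With compound 2 sitting at the limit of > 10 uM in this assay, at which 1 of the 2 values shown sits, the assay may report only a limit for compound 3 as well.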

Compound 3, minimum effective concentration: 10 uM
Compound 3: middle estimate and measured number agree at the digits printed; low and high end bracket the measured number.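

In this assay, the aromatic carbon para to a large group, on the six-membered aromatic ring of carbon only, now carries its first measured step: no change at the digits printed from compound 1 to compound 3 (within the scatter). Within this single pair, fluoro in place of methyl leaves the read-out where it stood, which is something the earlier compounds could not show, as they offered no pair differing in one place. No measured property in the set bears on this step, so the flat result stands as an observation without an explanation.

Compound 2 remains a limit rather than a number, and it differs from the other two compounds in more than one place, so no step to it can be read: the limit of > 10 uM in this assay, at which 1 of the 3 values shown sits.

One exchange at one carbon also leaves the wider tolerance of this position open, including whether a methoxy group, an amine or a carboxylic acid on the same aromatic carbon would hold the read-out at the level of compound 3 or move it beyond the scatter.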